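The source may report more compounds than this note shows. Statements on the series, on what has been measured and on what is new or still open speak of the compounds shown alone.

Measured so far in a functional assay on HCT-15 cells (Homo sapiens) for cytotoxicity, read by ELISA, with a stated time of 2 days; a higher number here means a weaker inhibitor, a lower number a stronger inhibitor:
- compound 1 `Oc1cccc(-c2cc(-c3ccccc3)cc(-c3ccccc3)n2)c1` gives 9950 nM
- compound 2 `Oc1cccc(-c2cc(-c3ccccc3)cc(-c3ccncc3)n2)c1` gives 27400 nM
- compound 3 `Oc1cccc(-c2cc(-c3ccccc3)nc(-c3ccsc3)c2)c1` gives 24600 nM

Compound 3 at 24600 nM lies within the scatter of compound 2 at 27400 nM. Its number is higher than that of compound 1 at 9950 nM, a gap beyond the scatter.

Next is compound 4 `Oc1cccc(-c2cc(-c3ccccc3)nc(-c3cccnc3)c2)c1`, with pyridin-3-yl in place of thiophen-3-yl on an aromatic carbon, next to the ring nitrogen: pyridin-3-yl in place of thiophen-3-yl on an aromatic carbon.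

Within the data shown here, only one measured step bears on this, and only indirectly: a 2.8-fold higher number from compound 1 to compound 2 (0.44 log units; beyond the scatter). That modest step brings in pyridin-4-yl for phenyl, so both its leaving group and its entering group differ from those here, and the groups on the core of compound 1 are also arranged differently from those of compound 3. Among the measured compounds shown here, no measured step starts from thiophen-3-yl or brings in pyridin-3-yl. Compound 3 and compound 2 already share the same range in this assay, so no step beyond the scatter is expected, with at most a slight drift towards a higher number.

The expected change is a 1.1-fold higher number from compound 3 to compound 4 (0.06 log units; within the scatter).

For compound 4 the estimated value is 28000 nM, with an expected range from 12000 nM to 60000 nM.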

Compound 4, half-maximal inhibitory concentration: 18400 nM
Compound 4: middle estimate off by 1.5-fold (0.18 log units), on the high side; low and high end bracket the measured number.
By their numbers in this assay, from the lowest: compounds 1, 4, 3 and 2 (each within the scatter of the next, the first and the last beyond it).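

In this assay, pyridin-3-yl in place of thiophen-3-yl on the aromatic carbon next to the ring nitrogen gives a step within the scatter (a 1.3-fold lower number from compound 3 to compound 4 (0.13 log units; within the scatter)), so a five-membered and a six-membered aromatic ring, each with 1 hetero atom, are not separated at this place. Among these compounds, the only earlier step (a 2.8-fold higher number from compound 1 to compound 2 (0.44 log units; beyond the scatter)) lies beyond the scatter, but it involves neither of these groups and comes from a different arrangement of groups on the core, so this is the first direct reading at this place. No measured information on these compounds offers an explanation for this result.

On these data alone, whether a non-aromatic group at this place, such as an amine, a carboxylic acid or a longer alkyl chain, would give a step beyond the scatter in this assay remains open. Also open, as far as these compounds go, is whether the step from phenyl to pyridin-4-yl would recur at this place, where the groups on the core are arranged differently from those of compound 1.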